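The source may hold more compounds than are shown below. What is called first, only, known or untested is meant among the compounds shown, and "the series" means these compounds.

Compound 1 (`CCOC(=O)CCCCCOc1cccc(CN(C(=O)c2ccc(-c3cccc(N(C)C)c3)cc2)C(C)C)c1`): > 26000 nM as a limit
Compound 2 (`CCOC(=O)CCCCCOc1cccc(CN(C(=O)c2ccc(-c3ccc4c(c3)OCCO4)cc2)C(C)C)c1`): > 24400 nM as a limit

In an ADME assay on HepG2 cells (Homo sapiens) for cytotoxicity, read by CellTiter-Glo and resazurin assay, with a stated time of 72 h (on this read-out lower numbers stand for an effect already at smaller amounts and higher numbers for an effect only at larger amounts of compound), compound 2 stands only at a limit (> 24400 nM) and has no number. Compound 3 (`CCOC(=O)CCCCCOc1cccc(CN(C(=O)c2ccc(-c3cc(OC)ccc3F)cc2)C(C)C)c1`) differs from compound 2 in one group (2-fluoro-5-methoxyphenyl in place of 2,3-dihydro-1,4-benzodioxin-6-yl on an aromatic carbon) with 2-fluoro-5-methoxyphenyl in place of 2,3-dihydro-1,4-benzodioxin-6-yl on an aromatic carbon, para to a large group. Among the compounds with values here, the one measured step that bears on this is also a swap of that group (a step that the two limits leave unreadable from compound 1 to compound 2) and its size cannot be read. It points in neither direction, so no step beyond the usual scatter is expected, and this assay may well report only a limit again. The estimated change (a step that the limit leaves unreadable from compound 2 to compound 3) is expected to stay within the scatter. For compound 3 the expected value is 25000 nM (estimated range 13000 nM to 50000 nM).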

Compound 3, half-maximal effective concentration: > 26000 nM
Compound 3 was reported as a limit; the forecaster's own chance of this, stated with the estimate: 80%; at least 1.0-fold (0.01 log units) between middle value and limit.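

Compound 1, compound 2 and compound 3 all stand only as limits in this assay, and the steps between them cannot be read. The compounds shown leave open whether 3-(dimethylamino)phenyl, 2,3-dihydro-1,4-benzodioxin-6-yl and 2-fluoro-5-methoxyphenyl differ at all in this read-out.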